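Fluorine Added to a Non-Toxic Salicylamide Analogue

This account rests on a few compounds, and the source may have more. Where it says the series, first, only, none or still open, it means among the compounds named here.

Of the compounds shown here, three have been tested in an ADME assay on NCI-H630 cells (Homo sapiens) for cytotoxicity, read by MTT assay, with a stated time of 72 h; on this read-out higher numbers stand for lower toxicity in this test and lower numbers for higher toxicity in this test. Compound 1, `O=C(O)c1cc(OCc2ccccc2)ccc1O`, carries a free acid. Compound 1 gives > 40000 nM, which is a limit of the assay rather than a number. Compound 2, `O=C(O)c1cc(OCc2ccc(F)cc2)ccc1O`, differs from compound 1 by fluoro in place of hydrogen on an aromatic carbon. Compound 2 also gives > 40000 nM, again a limit of the assay. The step from compound 1 to compound 2 is therefore a step that the two limits leave unreadable from compound 1 to compound 2.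

Compound 3, `O=C(NCc1ccc(F)cc1)c1cccc(O)c1O`, has a different core from compound 1; the difference between the two cores is not broken down here. Compound 3 gives > 40000 nM, a limit of the assay as well. All three measured compounds thus share one feature: the limit of > 40000 nM in this assay, at which 3 of the 3 values shown sit.

Compound 4, `O=C(NCc1ccc(F)c(F)c1)c1cccc(O)c1O`, is not yet measured. It differs from compound 3 by fluoro in place of hydrogen on an aromatic carbon. This is the same kind of change as that from compound 1 to compound 2, but not the same: in compound 2 the fluoro enters para to a large group, whereas in compound 4 it enters ortho to a fluoro group and meta to a large group.

Among the compounds with values here, the step from compound 3 to compound 4 is expected to be a step that the limit leaves unreadable from compound 3 to compound 4, because every value so far sits at the limit described by the limit of > 40000 nM in this assay, at which 3 of the 3 values shown sit, and the first fluoro gave a step that the two limits leave unreadable from compound 1 to compound 2. Compound 4 is therefore estimated to give 50000 nM, with a plausible range from 20000 nM to 120000 nM.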

Compound 4, half-maximal cytotoxic concentration: > 40000 nM
Compound 4: no number, only a limit; the forecaster's own chance of this, stated with the estimate: 80%; the middle value does not contradict the limit.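

Within the data shown here, compound 4 gives only a limit of the assay, not a number, and so does compound 3, which leaves no step between them to read in this assay. The series as a whole stays at one result: the limit of > 40000 nM in this assay, at which 4 of the 4 values shown sit. The compounds shown leave open whether fluoro in place of hydrogen on an aromatic carbon changes the read-out at all, and what number any of these compounds would give.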